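A few compounds are considered here, and "the series" means these few. Any claim that something is new, unique, unknown or untested is made for them only; others in the source may bear on it.

Measured so far in a functional assay on SK-BR-3 cells (Homo sapiens) for antiproliferative activity, read by MTT assay, with a stated time of 72 h; a lower number here means a stronger inhibitor, a higher number a weaker inhibitor:
- compound 1 `CCN1CCN(c2cc(C)c3cc(NC(=O)c4ccc(C)cc4)ccc3n2)CC1`: 11400 nM
- compound 2 `CNc1cc(C)c2cc(NC(=O)c3ccc(Cl)c(Cl)c3)ccc2n1`: 6350 nM

For the measured compounds named here, compound 1 carries the higher of only two numbers, but the gap to compound 2 lies within the usual scatter, so the two cannot be ranked. Compound 3 `CCN1CCN(c2cc(C)c3cc(NC(=O)c4cccc(C)c4)ccc3n2)CC1` is not yet measured in this assay. It has the same atoms as compound 1, joined differently: 3-methylphenyl in place of 4-methylphenyl on a carbonyl carbon. Going by the values given here, no pair of measured compounds differs in one place, so the data give no guide to the effect of this change. Among the compounds with values here, the only anchor is compound 1 at 11400 nM. The expected step of a 1.1-fold lower number from compound 1 to compound 3 (0.06 log units; within the scatter) stays within the scatter, with no direction favoured. For compound 3 the estimated value is 10000 nM, with an expected range of 4500 nM to 22000 nM.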

Compound 3, half-maximal inhibitory concentration: 13700 nM
Compound 3: middle estimate off by 1.4-fold (0.14 log units), on the low side; low and high end bracket the measured number.
By their numbers in this assay, from the lowest: compounds 2, 1 and 3 (each within the scatter of the next, the first and the last beyond it).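

In this assay, for the compounds shown here, the swap of 4-methylphenyl for 3-methylphenyl on a carbonyl carbon gives a 1.2-fold higher number from compound 1 to compound 3 (0.08 log units; within the scatter) and is the first comparison that differs in one place. On this amide carbonyl, with the rest of the molecule held constant, the two methylphenyl isomers cannot be told apart, so this read-out shows no preference between them. Nothing measured here explains that result.

Going by these compounds, whether a methoxy group, a nitrile or a carboxylic acid in place of the methyl on this phenyl ring would shift the number beyond the scatter remains open. Compound 1 and compound 2 differ in more than one place, and their values give no reading of any other part of the molecule.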